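Compound 3: an amide in place of the ketone

This account rests on a few compounds, and the source may have more. Where it says the series, first, only, none or still open, it means among the compounds named here.

Measured so far in a functional assay on HCT-116 cells (Homo sapiens) for inhibition, read by MTT assay, with a stated time of 48 h (on this read-out higher numbers stand for weaker inhibition and lower numbers for stronger inhibition), for this series:
- Compound 1 `COc1ccc(-n2c(SCC(=O)c3ccccc3)nnc2-c2cc(OC)c(OC)c(OC)c2)cc1` gives > 60000 nM (a limit, not a number)
- Compound 2 `COc1cc(-c2nnc(SCC(=O)c3ccccc3)n2-c2ccc(N(C)C)cc2)cc(OC)c1OC` gives 42500 nM (a number)

Among the measured compounds shown here, compound 2, at 42500 nM in this series, holds the only actual number. Compound 1 has only a limit (the limit of > 60000 nM in this assay, at which 1 of the 2 values shown sits) and no number.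

Compound 3 `COc1ccc(NC(=O)CSc2nnc(-c3cc(OC)c(OC)c(OC)c3)n2-c2ccc(N(C)C)cc2)cc1` keeps the rest of compound 2 and changes one place: (4-methoxyphenyl)amino in place of phenyl on a carbonyl carbon in words, (4-methoxyphenyl)amino in place of phenyl on a carbonyl carbon, so benzoylmethyl becomes ((4-methoxyphenyl)carbamoyl)methyl.

For the measured compounds named here, the one measured step is an at least 1.4-fold lower number from compound 1 to compound 2 (0.14 log units; that floor lies within the scatter) and it concerns dimethylamino in place of methoxy on an aromatic carbon, a different place. Going by the values given here, it therefore gives little guidance on size, and no measured step covers the new change. Compound 2, at 42500 nM for now, already stands high on this read-out, so a lower number is the more likely direction. In this assay the expected change is a 2.1-fold lower number from compound 2 to compound 3 (0.33 log units; beyond the scatter) as a modest estimate with wide uncertainty. The estimated value for compound 3 is 20000 nM and the expected range runs from 5000 nM to 60000 nM in this assay.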

Compound 3, half-maximal inhibitory concentration: > 60000 nM
Compound 3 ended at the assay's limit; the forecaster's own chance of this, stated with the estimate: 25%; middle value at least 3.0-fold (0.47 log units) away from the limit.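

In this assay compound 3 gives > 60000 nM, which is a limit of the assay and not a number. Among the compounds shown here, at this position, (4-methoxyphenyl)amino in place of phenyl on a carbonyl carbon gives an at least 1.4-fold higher number from compound 2 to compound 3 (0.14 log units; that floor lies within the scatter), so the true size of the step remains unknown and the change brings no lower number than the one held by compound 2. The earlier compounds showed nothing about this end of the molecule, and the new reading adds it to a series that still crowds at the top of the read-out: the limit of > 60000 nM in this assay, at which 2 of the 3 values shown sit.

Compound 3 changes the atom joined to the carbonyl and adds a methoxy-bearing ring in a single step, and the compounds shown do not separate these two parts of the change. Also open, going by these compounds, is how this position reads with an unsubstituted phenylamino, a carboxylic acid or a longer chain in place of the benzoylmethyl of compound 2, and whether any of these gives a clearly lower number than compound 2.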